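From an Aryl Amide to a Benzyl Amide

The source may report more compounds than this note shows. Statements on the series, on what has been measured and on what is new or still open speak of the compounds shown alone.

Compound 2 `COc1ccc2c(=O)c(/C=C/C(=O)Nc3ccccc3Cl)coc2c1` carries a 2-chlorophenyl group on its amide nitrogen. For the measured compounds named here, in a functional assay on Huh-7 cells (Homo sapiens) for inhibition, read by MTT assay, with a stated time of 48 h (on this read-out lower numbers stand for stronger inhibition and higher numbers for weaker inhibition), compound 2 gives 58400 nM, the highest of the two numbers measured so far. The nearest neighbour is compound 1 `O=C(/C=C/c1coc2cc(O)ccc2c1=O)NCc1ccccc1`, which in this assay gives 4690 nM, a markedly lower number. Compound 3 `COc1ccc(NC(=O)/C=C/c2coc3cc(O)ccc3c2=O)cc1` gives in this assay only a limit, > 100000 nM, so no number is known for it; this is the limit of > 100000 nM in this assay, at which 1 of the 3 values shown sits.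

Compound 4 `COc1ccc(CNC(=O)/C=C/c2coc3cc(OC)ccc3c2=O)cc1` has not yet been measured. It differs from compound 2 in one place: 4-methoxybenzyl in place of 2-chlorophenyl on an amide-type nitrogen. Going by the values given here, the single measured step that bears on this change is an at least 21-fold higher number from compound 1 to compound 3 (1.32 log units; beyond the scatter), and it runs the opposite way, replacing a benzyl group with an aryl group on the amide nitrogen and weakening inhibition sharply. Compound 4 goes from an aryl group back to a benzyl group, so a lower number in this assay is expected, though the starting aryl group and the shared core differ from those of compound 1 and compound 3. The step from compound 2 to compound 4 is therefore estimated as a 4.9-fold lower number from compound 2 to compound 4 (0.69 log units; beyond the scatter). Compound 4 is expected to give about 12000 nM, most likely between 3000 nM and 50000 nM.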

Compound 4, half-maximal inhibitory concentration: 7570 nM
The estimate for compound 4 lay 1.6-fold (0.20 log units) above the measured number, and the stated range covers the measured number.
By their numbers in this assay, from the lowest: compounds 1 and 4 (each within the scatter of the next); then compound 2. At a limit, above all of these: compound 3.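

In this assay, the change from an aryl group to a benzyl-type group on the amide nitrogen now has a step with a measured number at both ends: a 7.7-fold lower number from compound 2 to compound 4 (0.89 log units; beyond the scatter). The earlier step of this kind involved compound 3, which gives only a limit and not a number: the limit of > 100000 nM in this assay, at which 1 of the 4 values shown sits. The result also extends the direction to a second version of the core, as compound 2 and compound 4 carry a methoxy group where compound 1 and compound 3 carry a hydroxyl group, and in both pairs the compound with the benzyl-type group has the lower number.

This single change removes the chlorine, adds a methoxy group and adds the benzyl carbon all at once, so the compounds shown cannot tell which of these parts goes with the lower number. Also open, from the compounds shown here alone, is how a longer chain such as phenethyl on the amide nitrogen, or an amine or a carboxylic acid on the ring of the benzyl group, would read on this core.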